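The compounds below may be only part of what the source reports. "The series", "measured", "known", "first", "only" and "open" are said of these compounds alone.

Measured so far:
compound 1 `C#CC(C)OC(=O)c1ccc(C(CC)(CC)c2ccc(OCC(O)C(C)(C)C)c(C)c2)n1CC` — 200 nM
compound 2 `CCOc1ccc(NC(=O)c2ccc(C(CC)(CC)c3ccc(OCC(=O)C(C)(C)C)c(C)c3)n2CC)cc1` — > 50000 nM

In an assay on HL-60 cells for agonist activity at vitamin D3 receptor (Homo sapiens), read by microscopy, with a stated time of 96 h (on this read-out lower numbers stand for an effect already at smaller amounts and higher numbers for an effect only at larger amounts of compound), compound 1 gives 200 nM. For compound 2 the read-out is only a limit, > 50000 nM, and it sits at the limit of > 50000 nM in this assay, at which 1 of the 2 values shown sits, rather than at a number. Compound 2 therefore stands at the weak end of what has been measured, with no numerical value of its own.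

Compound 3 `CCOc1ccc(NC(=O)c2ccc(C(CC)(CC)c3ccc(OCC(O)C(C)(C)C)c(C)c3)n2CC)cc1` is not yet measured. It differs from compound 2 in one place: 1-hydroxy-2,2-dimethylpropyl in place of (tert-butyl)carbonyl on a saturated chain carbon bound to an oxygen on an aromatic ring. Within the data shown here, the hydroxy chain that enters is the same side chain carried by compound 1, the only compound here with a numerical value. Among the measured compounds shown here, no measured step covers this change, so the size of the step is open; the expected direction is toward lower concentrations, beyond the scatter, given that compound 2 sits at a limit. The step from compound 2 to compound 3 is estimated as an at least 33-fold lower number from compound 2 to compound 3 (1.52 log units; beyond the scatter). Compound 3 is expected to give about 1500 nM, within 150 nM to 20000 nM.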

Compound 3, half-maximal effective concentration: 630 nM
Beside the measured number, compound 3's estimate is 2.4-fold (0.38 log units) above it; measured number inside the range.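

In this assay, this position now has a reading for both chains on an otherwise unchanged structure: 1-hydroxy-2,2-dimethylpropyl in place of (tert-butyl)carbonyl, on a saturated chain carbon bound to an oxygen on an aromatic ring, gives an at least 79-fold lower number from compound 2 to compound 3 (1.89 log units; beyond the scatter). The reading of compound 2 is a limit and not a number: the limit of > 50000 nM in this assay, at which 1 of the 3 values shown sits.
With the hydroxy chain held constant, (4-ethoxyphenyl)amino in place of (1-methylprop-2-yn-1-yl)oxy on a carbonyl carbon gives only a modest step, a 3.2-fold higher number from compound 1 to compound 3 (0.50 log units; beyond the scatter).

Going by these compounds, whether an amine or a methyl ether in place of the hydroxy group on this chain would keep the number near that of compound 3 remains open. Also open, on these data alone, is whether (tert-butyl)carbonyl on the core of compound 1 would give a similarly large step.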